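The source may hold more compounds than are shown below. What is called first, only, known or untested is meant among the compounds shown, and "the series" means these compounds.

Compound 1 `Cc1ccc(-c2c(C)c(-c3ccc(C)c(C)c3)c(C(OC(C)(C)C)C(=O)O)c(C)c2NS(=O)(=O)C2CC2)cc1C` is the most cytotoxic of the three measured compounds in an ADME assay on MT4 cells (Homo sapiens) for cytotoxicity, read by MTT assay, with a stated time of 4 days (on this read-out lower numbers stand for higher toxicity in this test and higher numbers for lower toxicity in this test), where compound 1 gives 11000 nM. Compound 2 `Cc1ccc(-c2c(C)c(-c3ccc(Cl)cc3)c(C(OC(C)(C)C)C(=O)O)c(C)c2NS(C)(=O)=O)cc1C` gives 26000 nM in this assay, and compound 3 `Cc1ccc(-c2c(C)c(-c3ccc4c(c3)CCCO4)c(C(OC(C)(C)C)C(=O)O)c(C)c2NS(C)(=O)=O)cc1C` gives 28000 nM; both of these numbers lie beyond the scatter above that of compound 1. Going by the values given here, the only measured step that changes a single place is the one on the aryl substituent, a 1.1-fold higher number from compound 2 to compound 3 (0.03 log units; within the scatter), which shows that swapping one aryl group for another leaves the read-out essentially unchanged.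

Compound 4 `Cc1ccc(-c2c(C)c(-c3ccc(C)c(C)c3)c(C(OC(C)(C)C)C(=O)O)c(C)c2NS(=O)(=O)c2ccccc2)cc1C` is not yet measured. It differs from compound 1 in one place: phenyl in place of cyclopropyl on a sulfonyl sulfur. Among the compounds with values here, no measured step touches the sulfonyl substituent, so the shape of this change has no direct precedent among the three measured compounds; compound 2 and compound 3 carry a methylsulfonyl group instead, and their numbers only show that compound 1 with its cyclopropylsulfonyl group is the lower of the two arrangements. On that basis the step of a 1.2-fold lower number from compound 1 to compound 4 (0.09 log units; within the scatter) is expected to be small, with the direction uncertain. For compound 4 the estimate in this assay is 9000 nM, with a range from 3000 nM to 30000 nM.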

Compound 4, half-maximal cytotoxic concentration: 11000 nM
The estimate for compound 4 lay 1.2-fold (0.09 log units) below the measured number, within the range that was stated.
By their numbers in this assay, from the lowest: compounds 1 and 4 (each within the scatter of the next); then compounds 2 and 3 (each within the scatter of the next).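

Going by these compounds alone, the exchange of cyclopropyl for phenyl on the sulfonyl sulfur gives the first direct reading at this place, and this assay shows no change at the digits printed from compound 1 to compound 4 (within the scatter) with the rest of the molecule held constant. A three-membered non-aromatic ring and a six-membered aromatic ring are therefore interchangeable on this read-out, at least in the setting of compound 1, so this one exchange gives no sign that the read-out depends on the size or the ring type of the group at this place. Nothing on hand offers an explanation for this result.

Compounds 2 and 3 differ from compound 1 and compound 4 in more than one place, so the compounds shown do not settle whether the sulfonyl substituent has any part in the gap between those two pairs, and a direct exchange to methyl on the core of compound 1 would be needed to test that. Also open, as far as these compounds go, is whether a group of a different kind on the sulfonyl sulfur, such as a dimethylamino group, a straight butyl chain or a pyridine ring, would leave the number just as it stands.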